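Swapping an amide aryl group: compound 3 to compound 4

This account rests on a few compounds, and the source may have more. Where it says the series, first, only, none or still open, it means among the compounds named here.

Three compounds share one core and differ only in the aryl group attached to the amide carbonyl. Compound 1 `Cc1ccc(C(=O)Nc2cccc(-c3oc4cc(-c5ccc(F)cc5)ccc4c(=O)c3O)c2)cc1` gives 2320 nM in a functional assay on HepG2 cells (Homo sapiens) for antiproliferative activity, read by CCK-8 assay, with a stated time of 72 h; on this read-out lower numbers stand for stronger inhibition and higher numbers for weaker inhibition. Compound 2 `O=C(Nc1cccc(-c2oc3cc(-c4ccc(F)cc4)ccc3c(=O)c2O)c1)c1ccc(Br)cc1` gives 13900 nM, and compound 3 `COc1cccc(C(=O)Nc2cccc(-c3oc4cc(-c5ccc(F)cc5)ccc4c(=O)c3O)c2)c1` gives 9950 nM. Compound 3 therefore stands second highest of the three numbers: its distance from compound 2 is within the scatter, while compound 1 sits well below it, as the step of a 4.3-fold higher number from compound 1 to compound 3 (0.63 log units; beyond the scatter) shows.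

Compound 4 `CCc1ccc(C(=O)Nc2cccc(-c3oc4cc(-c5ccc(F)cc5)ccc4c(=O)c3O)c2)cc1` has not yet been measured. The change from compound 3 to compound 4 is 4-ethylphenyl in place of 3-methoxyphenyl on a carbonyl carbon. Among the measured compounds shown here, the step that bears most on this is the one from compound 1 to compound 3, a 4.3-fold higher number from compound 1 to compound 3 (0.63 log units; beyond the scatter), since compound 1 also carries an alkyl group on that phenyl ring and its number is the lowest of the three. The step of a 1.4-fold lower number from compound 2 to compound 3 (0.15 log units; within the scatter) adds little, being within the scatter. Returning to a 4-alkylphenyl is thus expected to bring the number back down toward that of compound 1, a step estimated as a 4.0-fold lower number from compound 3 to compound 4 (0.60 log units; beyond the scatter).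

Compound 4 is expected to give about 2500 nM in this assay, with a range from 1000 nM to 6500 nM.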

Compound 4, half-maximal inhibitory concentration: 20600 nM
Compound 4: the middle estimate sits 8.2-fold (0.92 log units) below what was measured; measured number outside the range, above it.
By their numbers in this assay, from the lowest: compound 1; then compounds 3, 2 and 4 (each within the scatter of the next, the first and the last beyond it).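

Going from 4-methylphenyl to the slightly longer 4-ethylphenyl, with methyl in place of hydrogen on the chain carbon bound to the aromatic carbon, gives an 8.9-fold higher number from compound 1 to compound 4 (0.95 log units; beyond the scatter) in this assay, so a very small extension at this position can weaken the antiproliferative effect considerably. Having an alkyl group on this phenyl ring is therefore not enough for a low number, since 4-ethylphenyl in place of 3-methoxyphenyl gives a 2.1-fold higher number from compound 3 to compound 4 (0.32 log units; beyond the scatter) rather than a lower value. Ethyl in place of bromo gives a 1.5-fold higher number from compound 2 to compound 4 (0.17 log units; within the scatter), a step that does not separate these two groups, and among the four compounds only compound 1 stands apart from the rest.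

On these data alone, it remains open whether an unsubstituted phenyl ring, a 4-chlorophenyl group, a longer chain such as 4-propylphenyl or a ring carrying an amine would give a number near that of compound 1 or near the higher group. No measurement here offers an explanation for why the ethyl group behaves so differently from the methyl group.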